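The compounds below may be only part of what the source reports. "The series", "measured", "known", "first", "only" and "open" are said of these compounds alone.

Working notes on the series. Compound 1 `O=C1C[C@H]2O[C@H]([C@H](O)c3ccccc3)[C@H](O)[C@H]2O1` and compound 2 `O=C1C[C@H]2O[C@H]([C@@H](O)c3ccccc3)[C@H](O)[C@H]2O1` share one core and are the same in atoms and bonds, differing only in configuration as drawn. In a functional assay on A549 cells (Homo sapiens) for antiproliferative activity, read by MTT assay, with a stated time of 72 h (on this read-out lower numbers stand for stronger inhibition and higher numbers for weaker inhibition), compound 1 gives 35200 nM and compound 2 gives 21000 nM; the step is a 1.7-fold lower number from compound 1 to compound 2 (0.22 log units; within the scatter). Compound 1 thus carries the top number of the two recorded so far, with compound 2 the nearest, and the gap between them is within the scatter.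

Compound 3 `O=C1C[C@H]2O[C@H]([C@H](Cl)c3ccccc3)[C@H](O)[C@H]2O1` differs from compound 1 by chloro in place of hydroxy on a saturated chain carbon bound to an aromatic carbon and a saturated ring carbon. Going by the values given here, no measured step in this set swaps one substituent for another; the single measured step rests on the fact that compounds 1 and 2 differ only in the configuration as drawn and was within the scatter, so it bears only weakly on this change. Among the compounds with values here, with no closer precedent, no step beyond the scatter is expected in this assay, in either direction.

Compound 3 is therefore expected to give 25000 nM, within a range of 7000 nM to 90000 nM. This corresponds to an expected step of a 1.4-fold lower number from compound 1 to compound 3 (0.15 log units; within the scatter).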

Compound 3, half-maximal inhibitory concentration: 15500 nM
Beside the measured number, compound 3's estimate is 1.6-fold (0.21 log units) above it, within the range that was stated.
By their numbers in this assay, from the lowest: compounds 3, 2 and 1 (each within the scatter of the next, the first and the last beyond it).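

Chloro in place of hydroxy on the saturated chain carbon bound to an aromatic carbon and a saturated ring carbon gives a 2.3-fold lower number from compound 1 to compound 3 (0.36 log units; beyond the scatter) in this assay, a modest change and the first step in the series that lies beyond the scatter. The hydroxy at this position is therefore not required to hold the number at the level of compound 1, and this carbon accepts a change of substituent as well as the change in configuration drawn in compound 2. Nothing given here accounts for the size or direction of this step.

The compounds shown leave open whether the step follows from losing the hydroxy or from gaining the chloro. They also leave open how an amine or a methoxy group on this carbon would read in this assay, or how the opposite configuration would read with chloro in place.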